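Chain analogues of compound 1 in the electroshock model

A few compounds are considered here, and "the series" means these few. Any claim that something is new, unique, unknown or untested is made for them only; others in the source may bear on it.

Compound 1, `c1ccc(CCc2cccc(N3CCNCC3)n2)cc1`, carries a phenyl on the saturated chain two bonds from the aromatic carbon of the core. In a functional assay on the whole organism with Mus musculus as the target, in the maximal electroshock model, with a stated time of 120 min (on this read-out lower numbers stand for an effect already at smaller amounts and higher numbers for an effect only at larger amounts of compound), compound 1 gives only a limit, > 300 mg/kg, so its place among the measured values is known only as sitting at the limit (the limit of > 300 mg/kg in this assay, at which 1 of the 3 values shown sits). Compound 2, `CCCCCCc1cccc(N2CCNCC2)n1`, gives 10 mg/kg in this assay. Compound 3, `CCCCCCCc1cccc(N2CCCNCC2)n1`, with a heptyl chain and a widened saturated ring on the core, gives 30 mg/kg in this assay; no single-point comparison connects compound 3 to compound 2.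

Compound 4, `CCCCCc1cccc(N2CCNCC2)n1`, is yet to be measured. It differs from compound 1 as follows: propyl in place of phenyl on a saturated chain carbon, two bonds along the chain from an aromatic carbon. For the measured compounds named here, the only measured step that bears on this change is an at least 30-fold lower number from compound 1 to compound 2 (1.47 log units; beyond the scatter), in which a four-carbon chain took the place of the phenyl. Compound 4 carries a three-carbon chain at the same place, so a step of the same direction is expected, plausibly of similar size, given that the shorter chain in compound 4 is still a plain alkyl without a ring.

Compound 4 is therefore expected to give 20 mg/kg in this assay, within 5 mg/kg to 100 mg/kg. The expected step is an at least 15-fold lower number from compound 1 to compound 4 (1.17 log units; beyond the scatter).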

Compound 4, minimum effective dose: 10 mg/kg
Estimate against measurement, compound 4: 2.0-fold (0.30 log units) above; the range from low to high includes it.
By their numbers in this assay, from the lowest: compounds 2 and 4 (each within the scatter of the next); then compound 3. At a limit, above all of these: compound 1.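

Propyl in place of phenyl, on a saturated chain carbon, two bonds along the chain from an aromatic carbon, gives an at least 30-fold lower number from compound 1 to compound 4 (1.47 log units; beyond the scatter) in this assay, so butyl is no longer the only plain alkyl group shown to stand far from the phenyl at this place. Hydrogen in place of methyl, on a saturated chain carbon, five bonds along the chain from an aromatic carbon, gives no change at the digits printed from compound 2 to compound 4 (within the scatter), so the printed values do not separate these two chain lengths. Compound 1 stands at a limit, so the step from it gives only a bound and not a full size: the limit of > 300 mg/kg in this assay, at which 1 of the 4 values shown sits.

The compounds shown leave open how far the chain can be shortened at this place, as with an ethyl or methyl group on the shared core, and whether an amine or a carboxylic acid at the chain end would be tolerated. Also open, from the compounds shown here alone, is whether the gap from compound 1 goes with the aromatic ring itself, which a cyclohexyl group in place of the phenyl would test.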